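Ethyl in place of oxetan-3-yl on an oxygen

The compounds below may be only part of what the source reports. "The series", "measured", "known", "first", "only" and "open" are said of these compounds alone.

In an ADME assay on microsomes from liver (Homo sapiens) for metabolic stability (on this read-out lower numbers stand for slow clearance and higher numbers for fast clearance), compound 1 `O=C(Nc1cccc(Cl)c1)N1CCc2[nH]nc(-c3ccccc3)c2C1` gives 192 mL/min/kg, compound 2 `O=C(Nc1cccc(Cl)c1)N1CCc2[nH]nc(C(=O)N3CCCCO3)c2C1` gives 38 mL/min/kg and compound 3 `CN(OC1COC1)C(=O)c1n[nH]c2c1CN(C(=O)Nc1cccc(Cl)c1)CC2` gives 8 mL/min/kg, the lowest of the three numbers. Compound 4 `CCON(C)C(=O)c1n[nH]c2c1CN(C(=O)Nc1cccc(Cl)c1)CC2` differs from compound 3 by ethyl in place of oxetan-3-yl on an oxygen. For the measured compounds named here, no measured step isolates this exchange. The closest guide is a 4.8-fold lower number from compound 2 to compound 3 (0.68 log units; beyond the scatter), a modest step that ends on the oxetan-3-yl group. The larger 24-fold lower number from compound 1 to compound 3 (1.38 log units; beyond the scatter) starts from phenyl and says less. A modest rise in this assay is therefore expected, partly undoing the first of these steps. The expected change is a 2.5-fold higher number from compound 3 to compound 4 (0.40 log units; beyond the scatter). For compound 4 the estimated clearance is 20 mL/min/kg, with an expected range of 9 mL/min/kg to 45 mL/min/kg.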

Compound 4, clearance: 55 mL/min/kg
Compound 4: the middle estimate sits 2.8-fold (0.44 log units) below what was measured; the measured number lies above the stated range.
By their numbers in this assay, from the lowest: compound 3; then compounds 2 and 4 (each within the scatter of the next); then compound 1.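

In this assay, ethyl in place of oxetan-3-yl on this oxygen gives a clear rise (a 6.9-fold higher number from compound 3 to compound 4 (0.84 log units; beyond the scatter)), so the low number of compound 3 does not hold for every small group here. With ethyl, the open-chain ethoxy(methyl)carbamoyl stands level with the ring amide of compound 2 (a 1.4-fold higher number from compound 2 to compound 4 (0.16 log units; within the scatter)) and still keeps a step down from phenyl (a 3.5-fold lower number from compound 1 to compound 4 (0.54 log units; beyond the scatter)). Nothing measured explains the size of the oxetan-3-yl to ethyl step.

With only these two groups on the oxygen, the effect of the ring cannot be separated from that of its oxygen. Cyclobutyl and 2-methoxyethyl at this place would separate them.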